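Fluoro in place of methyl on the amide side chain

A few compounds are considered here, and "the series" means these few. Any claim that something is new, unique, unknown or untested is made for them only; others in the source may bear on it.

Compound 1 `O=C(Nc1cccc(-c2oc3cc(-c4ccc(F)cc4)ccc3c(=O)c2O)c1)c1ccc(F)cc1`: 8590 nM
Compound 2 `Cc1ccc(C(=O)Nc2cccc(-c3oc4cc(-c5ccc(F)cc5)ccc4c(=O)c3O)c2)cc1`: 2400 nM
Compound 3 `Cc1cccc(C(=O)Nc2cccc(-c3oc4cc(-c5ccc(F)cc5)ccc4c(=O)c3O)c2)c1`: 7850 nM

Three compounds sharing one core were measured in a functional assay on MCF7 cells (Homo sapiens) for antiproliferative activity, read by CCK-8 assay, with a stated time of 72 h; a lower number here means a stronger inhibitor, a higher number a weaker inhibitor. Compound 2 gives 2400 nM, compound 1 gives 8590 nM, and compound 3 gives 7850 nM. The change from compound 2 to compound 1 is fluoro in place of methyl on an aromatic carbon; it made a 3.6-fold higher number from compound 2 to compound 1 (0.55 log units; beyond the scatter). Compound 3 differs from compound 2 by 3-methylphenyl in place of 4-methylphenyl on a carbonyl carbon, which gave a 3.3-fold higher number from compound 2 to compound 3 (0.51 log units; beyond the scatter). Compound 4 `O=C(Nc1cccc(-c2oc3cc(-c4ccc(F)cc4)ccc3c(=O)c2O)c1)c1cccc(F)c1` is not yet measured. It differs from compound 3 by fluoro in place of methyl on an aromatic carbon. This is the same kind of change as that from compound 2 to compound 1, but here the place is meta to a large group rather than para to a large group. Because the earlier change gave a 3.6-fold higher number from compound 2 to compound 1 (0.55 log units; beyond the scatter), a step in the same direction is expected, a 2.3-fold higher number from compound 3 to compound 4 (0.36 log units; beyond the scatter), though it may be smaller at this different place. Compound 4 is therefore estimated at 18000 nM, within a range from 7000 nM to 45000 nM.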

Compound 4, half-maximal inhibitory concentration: 5770 nM
Beside the measured number, compound 4's estimate is 3.1-fold (0.49 log units) above it, outside the stated range (below it).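

In this assay, fluoro in place of methyl gave a 1.4-fold lower number from compound 3 to compound 4 (0.13 log units; within the scatter), so the step seen at the para place did not carry over to the meta place: the same change on two cores in this assay, a 3.6-fold higher number (0.55 log units; beyond the scatter) from compound 2 to compound 1 and a 1.4-fold lower number (0.13 log units; within the scatter) from compound 3 to compound 4, 4.9-fold (0.69 log units) apart, beyond the scatter of two such steps Alongside this, 3-fluorophenyl in place of 4-fluorophenyl gave a 1.5-fold lower number from compound 1 to compound 4 (0.17 log units; within the scatter), while 3-fluorophenyl in place of 4-methylphenyl gave a 2.4-fold higher number from compound 2 to compound 4 (0.38 log units; beyond the scatter), which leaves compound 2 as the strongest of the four. This shows that the size of the step depends on the setting, but it rests on one pair at each place and does not show why the two steps differ.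

From the compounds shown here alone, whether a chloro, a methoxy or an amine at either place would match compound 2 or the other three remains open.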